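The source may hold more compounds than are shown below. What is called first, only, known or untested is meant among the compounds shown, and "the series" means these compounds.

Measured compounds:
- Compound 1, `C=C1C[C@]23C[C@@]1(O)CC[C@H]2c1cc(Br)c(O)c(C)c1[C@@H]3Cn1cc(-c2ccc(OC)cc2)nn1`: in a functional assay on HL-60 cells (Homo sapiens) for cytotoxicity, read by MTT assay, with a stated time of 4 days (on this read-out higher numbers stand for weaker inhibition and lower numbers for stronger inhibition), compound 1 gives only a limit, > 20000 nM.
- Compound 2, `C=C1C[C@]23C[C@@]1(O)CC[C@H]2c1cc(Br)c(O)c(C)c1[C@@H]3Cn1cc(-c2ccccc2)nn1`: in this assay compound 2 gives only a limit, > 20000 nM.

Neither of these values is a number; each is a limit of the assay, and both sit at the limit of > 20000 nM in this assay, at which 2 of the 2 values shown sit. On the numbers shown, compound 2 therefore has no measured position of its own: it sits at the limit, and the one further value available, that of compound 1, is a limit as well. Among the measured compounds shown here, the single measured step, a step that the two limits leave unreadable from compound 1 to compound 2, cannot be read, since both of its ends are limits.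

Compound 3, `C=C1C[C@]23C[C@@]1(O)CC[C@H]2c1cc(Br)c(O)c(C)c1[C@@H]3Cn1cc(-c2ccc(F)cc2)nn1`, differs from compound 2 by fluoro in place of hydrogen on an aromatic carbon. For the measured compounds named here, the only measured step bears on this change solely in that a different exchange on the same ring also left the value at the limit. Going by the values given here, with no step of readable size available, no direction beyond the scatter can be expected. The step from compound 2 to compound 3 is expected to be a step that the limit leaves unreadable from compound 2 to compound 3. Compound 3 is estimated at 30000 nM, with a range from 10000 nM to 100000 nM.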

Compound 3, half-maximal inhibitory concentration: 6600 nM
For compound 3 the middle estimate is 4.5-fold (0.66 log units) above the measured one; the measured number lies below the stated range.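

In this assay, the change from phenyl to 4-fluorophenyl brings an at least 3.0-fold lower number from compound 2 to compound 3 (0.48 log units; beyond the scatter), so a single fluorine atom at this place on the aromatic ring is enough to give a measurable value. Fluoro in place of methoxy at the same ring carbon brings an at least 3.0-fold lower number from compound 1 to compound 3 (0.48 log units; beyond the scatter), which shows that these two groups are not interchangeable here. The earlier pair could not show that this position matters at all, as the step between compound 1 and compound 2 cannot be read, with a limit at each end.

As far as these compounds go, how large the two new steps really are stays open, because the values they start from are limits: the limit of > 20000 nM in this assay, at which 2 of the 3 values shown sit. Whether another group at this place, such as chloro, an amine or a carboxylic acid, would also give a measurable value, and whether it would lie higher or lower than that of compound 3, cannot be told from these three compounds.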